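The source may hold more compounds than are shown below. What is called first, only, known or untested is meant among the compounds shown, and "the series" means these compounds.

Compound 1 `O=C(O)CCc1ccncc1-c1ccc2ccccc2c1` gives 101% in an assay on a protein complex for inhibition of CDK8/Cyclin C (Homo sapiens), with a stated time of 1 h, tested at 10 uM; on this read-out higher numbers stand for more inhibition at the one concentration tested (going by the name of the read-out) and lower numbers for less inhibition. Compound 2 `O=C(COc1ccncc1-c1ccc2ccccc2c1)N1CCOCC1` gives 9% in this assay.

Compound 2 stands lowest of the two numbers; the nearest, compound 1, sits higher by a margin beyond the usual scatter. Compound 3 `NNC(=O)COc1ccncc1-c1ccc2ccccc2c1` follows from compound 2 by one change: aminoamino in place of morpholin-4-yl on a carbonyl carbon. Among the measured compounds shown here, no step between measured compounds isolates such a change, so any expectation rests on compound 2 alone. A small upward step is expected, a number 16 percentage points higher from compound 2 to compound 3 (beyond the scatter), in this assay. Compound 3 is therefore estimated at 25%, with a range from 0% to 65%.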

Compound 3, a percentage reported as inhibition, at one concentration (the size of the read-out at that concentration, not a potency): 19%
Beside the measured number, compound 3's estimate is 6 percentage points above it; the range from low to high includes it.
By their numbers in this assay, from the lowest: compounds 2 and 3 (each within the scatter of the next); then compound 1.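

On a carbonyl carbon, aminoamino in place of morpholin-4-yl gives a number 10 percentage points higher from compound 2 to compound 3 (within the scatter) in this assay and so does not separate the two compounds. The whole substituent on the aromatic carbon matters far more: (aminocarbamoyl)methoxy in place of 2-carboxyethyl gives a number 82 percentage points lower from compound 1 to compound 3 (beyond the scatter) in this assay for that exchange. Nothing measured here explains either step. On these data alone, it remains open whether a carboxylic acid on the end of the methoxy chain, or a simple amine on that carbonyl carbon, would bring the number back towards that of compound 1.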